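Moving the methoxy group from compound 3 to compound 4

The source may hold more compounds than are shown below. What is called first, only, known or untested is meant among the compounds shown, and "the series" means these compounds.

Measured so far in a functional assay on BXPC-3 cells (Homo sapiens) for inhibition, read by MTT assay, with a stated time of 72 h; a lower number here means a stronger inhibitor of growth, a higher number a weaker inhibitor of growth:
Compound 1, `O=S(=O)(NCCCNCc1ccccc1Cl)c1cc(C(F)(F)F)cc(C(F)(F)F)c1`, gives 11000 nM.
Compound 2, `COc1ccc(CNCCCNS(=O)(=O)c2cc(C(F)(F)F)cc(C(F)(F)F)c2)cc1OC`, gives 13000 nM.
Compound 3, `COc1ccc(CNCCCNS(=O)(=O)c2cc(C(F)(F)F)cc(C(F)(F)F)c2)cc1`, gives 1300 nM.

Compound 3 stands lowest of the three numbers in this assay. Its nearest neighbour is compound 1, with an 8.5-fold lower number from compound 1 to compound 3 (0.93 log units; beyond the scatter), and its furthest is compound 2, with a 10-fold lower number from compound 2 to compound 3 (1.00 log units; beyond the scatter); both of these steps lie beyond the scatter, so compound 3 is the strongest inhibitor of growth among the compounds measured here. The step between compound 1 and compound 2 is a 1.2-fold higher number from compound 1 to compound 2 (0.07 log units; within the scatter).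

Compound 4, `COc1cccc(CNCCCNS(=O)(=O)c2cc(C(F)(F)F)cc(C(F)(F)F)c2)c1`, is not yet measured. It differs from compound 3 by 3-methoxyphenyl in place of 4-methoxyphenyl on a saturated chain carbon bound to an amine nitrogen. Going by the values given here, the steps seen so far bear on it only indirectly: they show that the substitution on this phenyl ring can move the number in this assay beyond the scatter, as the two steps into compound 3 did, but no measured pair compares a 4-methoxyphenyl with a 3-methoxyphenyl. Given that compound 3 holds the lowest number and the two neighbouring patterns gave higher numbers, compound 4 is expected to give a somewhat higher number than compound 3, with a 2.7-fold higher number from compound 3 to compound 4 (0.43 log units; beyond the scatter), and an estimate of 3500 nM, ranging from 1000 nM to 12000 nM.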

Compound 4, concentration for 50% growth inhibition: 1700 nM
For compound 4 the middle estimate is 2.1-fold (0.31 log units) above the measured one; low and high end bracket the measured number.
By their numbers in this assay, from the lowest: compounds 3 and 4 (each within the scatter of the next); then compounds 1 and 2 (each within the scatter of the next).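

In this assay, the methoxy group can stand in either of two places without a clear effect: 3-methoxyphenyl in place of 4-methoxyphenyl on a saturated chain carbon bound to an amine nitrogen gives a 1.3-fold higher number from compound 3 to compound 4 (0.12 log units; within the scatter). The advantage over the 3,4-dimethoxyphenyl group is therefore not confined to one single-methoxy pattern, since hydrogen in place of methoxy gives a 7.6-fold lower number from compound 2 to compound 4 (0.88 log units; beyond the scatter), a step of similar size to a 10-fold lower number from compound 2 to compound 3 (1.00 log units; beyond the scatter), and the comparison with the 2-chlorophenyl group gives a 6.5-fold lower number from compound 1 to compound 4 (0.81 log units; beyond the scatter). Nothing available here accounts for these steps.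

The compounds shown leave open whether the methoxy group itself matters at this position, as an ethoxy group, a hydroxyl group or an unsubstituted phenyl ring would test, and whether a 4-chlorophenyl group would keep the higher number of compound 1. They also leave open whether a single methoxy group would give the same result on a longer chain, or with a carboxylic acid or an amide in place of the sulfonamide.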